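Swapping the aryl amide for a cyclohexyl amide

The compounds below may be only part of what the source reports. "The series", "measured", "known", "first", "only" and "open" are said of these compounds alone.

Compound 3 `Cc1ccc(NC(=O)CN2CCN(c3cc4c(cc3F)c(=O)c(C(=O)O)cn4C3CC3)CC2)cc1` sits at the lowest of the two numbers in a functional assay on A549 cells (Homo sapiens) for antiproliferative activity, read by BrdU incorporation, with a stated time of 24 h (a higher number here means a weaker inhibitor, a lower number a stronger inhibitor), giving 23600 nM. Compound 2 `COc1ccc(NC(=O)CN2CCN(c3cc4c(cc3F)c(=O)c(C(=O)O)cn4C3CC3)CC2)cc1` gives 24800 nM, which lies within the scatter of compound 3. Compound 1 `COc1ccccc1NC(=O)CN1CCN(c2cc3c(cc2F)c(=O)c(C(=O)O)cn3C2CC2)CC1` reaches only a limit of this assay, > 100000 nM. Compound 4 `O=C(CN1CCN(c2cc3c(cc2F)c(=O)c(C(=O)O)cn3C2CC2)CC1)NC1CCCCC1` carries cyclohexyl in place of 4-methylphenyl on an amide-type nitrogen. The measured steps concern changes on the aromatic ring: an at least 4.0-fold lower number from compound 1 to compound 2 (0.60 log units; beyond the scatter) and an at least 4.2-fold lower number from compound 1 to compound 3 (0.62 log units; beyond the scatter), both resting on (the limit of > 100000 nM in this assay, at which 1 of the 3 values shown sits), and a 1.1-fold lower number from compound 2 to compound 3 (0.02 log units; within the scatter). Within the data shown here, none exchanges the aromatic ring for a saturated one, so the step to compound 4 has no direct precedent. Compound 4 is expected to differ from it by a 1.3-fold higher number from compound 3 to compound 4 (0.10 log units; within the scatter), probably within the scatter. Compound 4 is estimated at 30000 nM, between 10000 nM and 100000 nM.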

Compound 4, half-maximal inhibitory concentration: 20700 nM
Estimate against measurement, compound 4: 1.4-fold (0.16 log units) above, and the stated range covers the measured number.
By their numbers in this assay, from the lowest: compounds 4, 3 and 2 (each within the scatter of the next). At a limit, above all of these: compound 1.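

On this amide-type nitrogen, a non-aromatic cyclohexyl ring takes the place of an aromatic ring with no change beyond the scatter in this assay: the exchange gives a 1.1-fold lower number from compound 3 to compound 4 (0.06 log units; within the scatter) and a 1.2-fold lower number from compound 2 to compound 4 (0.08 log units; within the scatter). Measured against the 2-methoxyphenyl amide, the change gives an at least 4.8-fold lower number from compound 1 to compound 4 (0.68 log units; beyond the scatter), a step that rests on a limit rather than a number: the limit of > 100000 nM in this assay, at which 1 of the 4 values shown sits. Aromaticity of this ring therefore does not separate compound 4 from compound 2 or compound 3. The compounds shown leave open whether a straight butyl chain, or an amine on the cyclohexyl ring, would move the number beyond the scatter.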